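Methoxymethyl ether of compound 2 in MCF7 growth inhibition

The source may hold more compounds than are shown below. What is called first, only, known or untested is meant among the compounds shown, and "the series" means these compounds.

Measured compounds in a functional assay on MCF7 cells (Homo sapiens) for antiproliferative activity; a higher number here means a weaker inhibitor of growth, a lower number a stronger inhibitor of growth:
compound 1 `COc1cc(-c2nc3cc(F)ccc3s2)ccc1O` gives 750 nM.
compound 2 `COc1ccc(-c2nc3cc(F)ccc3s2)cc1OC` gives < 0.1 nM, which is a limit of the assay and not a number.
compound 3 `COc1ccc(-c2nc3cc(F)ccc3s2)c(OC)c1OC` gives 23 nM.

Compound 2 stands at the lower edge of what this assay reports, as the limit of < 0.1 nM in this assay, at which 1 of the 3 values shown sits, shows; its true number is not known, only that it lies beyond that limit. Compound 4 `COCOc1ccc(-c2nc3cc(F)ccc3s2)cc1OC` carries the change (methoxy in place of hydrogen on a saturated chain carbon bound to an oxygen on an aromatic ring). Within the data shown here, no measured step shows this change directly. The nearest are an at least 7500-fold lower number from compound 1 to compound 2 (3.87 log units; beyond the scatter), where a methyl on an oxygen on an aromatic ring was decisive, and an at least 230-fold higher number from compound 2 to compound 3 (2.36 log units; beyond the scatter), where an added methoxy on the ring cost much. Compound 4 keeps the methylated oxygen of compound 2 but lengthens that methyl to methoxymethyl. With compound 2 at a limit, the starting point is uncertain; a moderate loss is expected, an at least 10-fold higher number from compound 2 to compound 4 (1.00 log units; beyond the scatter), with compound 4 likely still potent. The estimate for compound 4 in this assay is 1 nM, between 0.05 nM and 30 nM.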

Compound 4, concentration for 50% growth inhibition: 65 nM
For compound 4 the middle estimate is 65-fold (1.81 log units) below the measured one; the measured number lies above the stated range.
By their numbers in this assay, from the lowest: compound 3; then compound 4; then compound 1. At a limit, below all of these: compound 2.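

In this assay, this oxygen does not accept every capping group: lengthening the methyl to methoxymethyl gives an at least 650-fold higher number from compound 2 to compound 4 (2.81 log units; beyond the scatter) and so ties the high potency of compound 2 to the methyl itself, not to capping of the oxygen as such. Methoxymethyl in place of the hydrogen on this oxygen still helps, with a 12-fold lower number from compound 1 to compound 4 (1.06 log units; beyond the scatter) as its step, yet this recovers only a small part of the gain seen with methyl in an at least 7500-fold lower number from compound 1 to compound 2 (3.87 log units; beyond the scatter) as the step. As far as these compounds go, compound 2 sits at a limit of the assay and not at a number, so the full size of the loss stays unknown: the limit of < 0.1 nM in this assay, at which 1 of the 4 values shown sits.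

The compounds shown leave open whether the added length or the added oxygen carries the loss. An ethyl or propyl ether at this oxygen would separate the two, and an amine on a longer chain would test the same place further out.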